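Added methoxy on the pyrazole-side aryl ring of compound 1

The compounds below may be only part of what the source reports. "The series", "measured", "known", "first", "only" and "open" are said of these compounds alone.

Compound 1 `COc1ccc(-c2cc(/C=C/C(=O)c3ccc(N)cc3)[nH]n2)cc1` gives -35% in a functional assay on RPMI-8226 cells (Homo sapiens) for cytotoxicity, read by sulforhodamine B assay, with a stated time of 48 h, tested at 10 uM (a higher number here means a weaker effect of the compound at the concentration tested, a lower number a stronger effect), the second highest of the three numbers recorded; compound 3 `COc1ccc(C(=O)/C=C/c2cc(-c3cc(OC)c(OC)c(OC)c3)n[nH]2)cc1OC` gives -50% and compound 2 `COc1cc(-c2cc(/C=C/C(=O)c3ccc(Cl)c(Cl)c3)[nH]n2)cc(OC)c1OC` gives -7%. Compound 4 `COc1ccc(-c2cc(/C=C/C(=O)c3ccc(N)cc3)[nH]n2)cc1OC` differs from compound 1 by methoxy in place of hydrogen on an aromatic carbon. Within the data shown here, the single recorded step, a number 43 percentage points lower from compound 2 to compound 3 (beyond the scatter), concerns the ring on the carbonyl carbon, not the ring changed here, so it does not bear directly on this change; no step alters the ring carrying the methoxy group. The expectation is therefore a step no larger than the scatter, a number 5 percentage points lower from compound 1 to compound 4 (within the scatter), with compound 4 estimated at -40%, in a range from -62% to -14%.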

Compound 4, a percentage reported as activity, at one concentration (the size of the read-out at that concentration, not a potency): -20%
Beside the measured number, compound 4's estimate is 20 percentage points below it; low and high end bracket the measured number.
By their numbers in this assay, from the lowest: compound 3; then compound 1; then compound 4; then compound 2.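

In this assay, methoxy in place of hydrogen on this aromatic carbon, ortho to a methoxy group and meta to a large group, gives a number 15 percentage points higher from compound 1 to compound 4 (beyond the scatter), so the added group weakens the effect at the concentration tested. Among these compounds, this is the first step on the ring carrying the methoxy group, and it shows that this carbon is not silent, whereas the earlier step concerned only the ring on the carbonyl carbon. No measurement at hand accounts for this step.

Open, as far as these compounds go, is whether a hydroxy group, an ethoxy group or a fluorine atom on this carbon would give a step of similar size and direction. Also open, from the compounds shown here alone, is whether the same methoxy step would recur with a different ring on the carbonyl carbon.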